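Replacing a benzoic acid arm with a short carboxylic chain

The source may hold more compounds than are shown below. What is called first, only, known or untested is meant among the compounds shown, and "the series" means these compounds.

The compounds here share a benzofuran-based core carrying a ketone to a phenyl ring, and they differ in the acid-bearing arm attached through an oxygen on that ring. In an assay on HEK293 cells for inhibition of solute carrier family 22 member 12 (Homo sapiens), read by scintillation counting, with a stated time of 8 min, tested at 100 nM (a higher number here means a stronger effect of the compound at the concentration tested, a lower number a weaker effect), compound 1, with structure `CCCCc1oc2ccccc2c1C(=O)c1ccc(OCc2ccc(C(=O)O)cc2)cc1`, gives 2%. Compound 2, with structure `CCc1oc2ccccc2c1C(=O)c1ccc(OCc2cccc(C(=O)O)c2)cc1`, gives 1% in this assay. Compound 3, with structure `CCc1oc2ccccc2c1C(=O)c1cc(Br)c(OCc2cccc(OCC(=O)O)c2)c(Br)c1`, gives 3% in this assay. Compound 3 does not stand apart from compound 1 or compound 2: all three numbers lie within the usual scatter of one another, so none of the three shows a clear effect at the tested concentration.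

Compound 4, with structure `CCc1oc2ccccc2c1C(=O)c1cc(Br)c(OCCCC(=O)O)c(Br)c1`, has not yet been measured. It differs from compound 3 in one place: 2-carboxyethyl in place of 3-(carboxymethoxy)phenyl on a saturated chain carbon bound to an oxygen on an aromatic ring. Since every measured arm gives essentially no inhibition, the step from compound 3 to compound 4 is expected to stay within the scatter, with no change in direction, as no change at the digits printed from compound 3 to compound 4 (within the scatter). For compound 4 the expected value in this assay is 3%, within a range from -5% to 12%.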

Compound 4, a percentage reported as inhibition, at one concentration (the size of the read-out at that concentration, not a potency): 6%
Compound 4: middle estimate off by 3 percentage points, on the low side, and the stated range covers the measured number.
By their numbers in this assay, from the lowest: compounds 2, 1, 3 and 4 (each within the scatter of the next).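

In this assay, placing 2-carboxyethyl in place of 3-(carboxymethoxy)phenyl on a saturated chain carbon bound to an oxygen on an aromatic ring gives a number 3 percentage points higher from compound 3 to compound 4 (within the scatter). Among the compounds shown here, the earlier compounds offered no pair differing in one place, so this is the first direct test of this position: the arm can lose its aromatic ring and shrink from 11 heavy atoms to 5 without the read-out moving beyond the scatter. No measurement shown here offers an explanation for this result.

Going by these compounds, all four compounds give little inhibition at the single concentration tested, so it remains open whether any arm at this position can produce a clear effect. A longer chain ending in the carboxylic acid, or an amine in place of that acid, could answer this.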